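The source may report more compounds than this note shows. Statements on the series, on what has been measured and on what is new or still open speak of the compounds shown alone.

Working notes on the series.

Three compounds share a common core and carry an aromatic ring at the same position. Compound 1 `Cc1ccc(-c2nc3c(=O)n(C)c(=O)n(C)c3[nH]2)cc1` bears a methyl on that ring; in an assay for binding affinity to adenosine receptor A1 (Bos taurus) (a lower number here means a stronger inhibitor, a higher number a weaker inhibitor), compound 1 gives 0.8 nM. Compound 2 `Cn1c(=O)c2nc(-c3ccc(Cl)cc3N)[nH]c2n(C)c1=O` carries a chloro together with an amino; in this assay compound 2 gives 0.35 nM. Compound 3 `Cn1c(=O)c2nc(-c3ccc([N+](=O)[O-])cc3N)[nH]c2n(C)c1=O` keeps the amino and carries a nitro in place of the chloro; in this assay compound 3 gives 2.5 nM. Compound 3 thus stands highest of the three numbers, with compound 1 nearest and compound 2 furthest from it.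

Going by the values given here, the only single-point step among the measured compounds is a 7.1-fold higher number from compound 2 to compound 3 (0.85 log units; beyond the scatter), and it is the one that bears on the change at hand, since the nitro is again the group that leaves.

Compound 4 `Cc1ccc(-c2nc3c(=O)n(C)c(=O)n(C)c3[nH]2)c(N)c1` is not yet measured. It differs from compound 3 by methyl in place of nitro on an aromatic carbon. The methyl is the group already present in compound 1, and compound 4 differs from compound 1 only by the amino; compound 2, which also carries the amino, gives the lowest number in this assay. A step of the order of the measured nitro step, but in the opposite direction, is expected, so that compound 4 is estimated at 0.5 nM in this assay, within 0.2 nM to 1.5 nM, which would mean a 5.0-fold lower number from compound 3 to compound 4 (0.70 log units; beyond the scatter).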

Compound 4, half-maximal inhibitory concentration: 10 nM
Compound 4: middle estimate off by 20-fold (1.30 log units), on the low side; the measured number lies above the stated range.
By their numbers in this assay, from the lowest: compound 2; then compound 1; then compound 3; then compound 4.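

With the amino group kept in place, methyl on this aromatic carbon gives the highest number in this assay, with a 4.0-fold higher number from compound 3 to compound 4 (0.60 log units; beyond the scatter) and a 29-fold higher number from compound 2 to compound 4 (1.46 log units; beyond the scatter), so the three groups rank chloro, then nitro, then methyl from the lowest number upward. The amino group also has a measurable step of its own on the methyl-bearing ring: amino in place of hydrogen gives a 13-fold higher number from compound 1 to compound 4 (1.10 log units; beyond the scatter), so in this pair the amino group goes with a higher number, not a lower one. No measurement among the data bears on why methyl and amino behave this way here.

The compounds shown leave open whether the amino step keeps its direction and size with chloro or nitro on this carbon in place of methyl. They also leave open how other groups at this position would fall relative to chloro, nitro and methyl, for example a methoxy, a carboxylic acid or a longer alkyl chain.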